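A few compounds are considered here, and "the series" means these few. Any claim that something is new, unique, unknown or untested is made for them only; others in the source may bear on it.

Compound 1 `COc1cc(/C=C/C(=O)c2cccc(-n3cc(-c4ccc(Cl)cc4)[nH]c3=O)c2)ccc1O`: 4670 nM
Compound 2 `COc1cc(/C=C/C(=O)c2cccc(-n3cc(-c4ccccc4)[nH]c3=O)c2)cc(OC)c1OC`: 3020 nM
Compound 3 `O=C(/C=C/c1cccc(O)c1)c1cccc(-n2cc(-c3ccccc3)[nH]c2=O)c1`: "not determined" (no result reported)

The three measured compounds share one core and differ at both ends. In a functional assay on TK-10 cells (Homo sapiens) for inhibition (on this read-out higher numbers stand for weaker inhibition of growth and lower numbers for stronger inhibition of growth), compound 2 gives 3020 nM, the lowest of the two numbers in hand. In this assay compound 1 gives 4670 nM, which lies within the usual scatter of the value for compound 2, so no order between the two can be read from these numbers. For compound 3 the result in this assay is "not determined" (no result reported), so no number is available for it.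

Compound 4 `COc1cc(/C=C/C(=O)c2cccc(-n3cc(-c4ccc(Cl)cc4)[nH]c3=O)c2)cc(OC)c1OC` has not yet been measured. It differs from compound 2 in one place: chloro in place of hydrogen on an aromatic carbon. Among the measured compounds shown here, no step between measured compounds isolates this change, so there is no measured pair from which its size could be taken. Compound 1 also carries a chloro group on that ring and gives 4670 nM in this assay, a number within the scatter of compound 2. On that basis the step of a 1.2-fold higher number from compound 2 to compound 4 (0.06 log units; within the scatter) is expected to stay within the scatter, with no clear direction. Compound 4 is therefore expected to give about 3500 nM in this assay, with a likely range from 1500 nM to 8000 nM.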

Compound 4, concentration for 50% growth inhibition: 6460 nM
Compound 4: the middle estimate sits 1.8-fold (0.27 log units) below what was measured; low and high end bracket the measured number.
By their numbers in this assay, from the lowest: compounds 2, 1 and 4 (each within the scatter of the next, the first and the last beyond it).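

In this assay, chloro in place of hydrogen on an aromatic carbon, para to a large group, gives a 2.1-fold higher number from compound 2 to compound 4 (0.33 log units; beyond the scatter). Among the compounds shown here, this is the first pair in which phenyl to 4-chlorophenyl stands alone, with the rest of the molecule unchanged, and it shows that at this position the change moves the number towards weaker inhibition of growth, though only modestly and only just past the usual scatter of repeated measurements. Nothing at hand accounts for the direction or size of this step.

The compounds shown leave open whether this step belongs to chloro in particular or would also appear with another group at the same position, such as fluoro, methyl, methoxy or an amine. For the compounds shown here, they also leave open whether the same change gives a step of similar size and direction when the other end of the molecule is not the one shared by compound 2 and compound 4, since this single pair is the only measure of it.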